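The source may hold more compounds than are shown below. What is called first, only, known or untested is meant among the compounds shown, and "the series" means these compounds.

Measured in a functional assay on HepG2 cells (Homo sapiens) for antiproliferative activity, read by MTT assay, with a stated time of 24 h; a lower number here means a stronger inhibitor, a higher number a weaker inhibitor:
- compound 1 `COc1ccc(C(=O)/C=C/c2cccc([N+](=O)[O-])c2)c2c1C=CC(C)(C)O2`: 2830 nM
- compound 2 `COc1ccc(/C=C/C(=O)c2ccc(OC)c3c2OC(C)(C)C=C3)cn1`: > 10000 nM

Compound 2 has only a limit of the assay, > 10000 nM, and no number. Compound 3 `COc1ccc(C(=O)/C=C/c2ccco2)c2c1C=CC(C)(C)O2` carries furan-2-yl in place of 6-methoxypyridin-3-yl on a double-bonded chain carbon bound to a double-bonded chain carbon. Going by the values given here, one measured step bears on this place: an at least 3.5-fold higher number from compound 1 to compound 2 (0.54 log units; beyond the scatter), beyond the scatter, with 6-methoxypyridin-3-yl entering. On that step alone, removing this group is expected to give a modest move towards a lower number in this assay. The expected size is an at least 1.6-fold lower number from compound 2 to compound 3 (0.22 log units; that floor lies within the scatter). The estimate for compound 3 is 6000 nM, with an expected range of 2000 nM to 18000 nM.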

Compound 3, half-maximal inhibitory concentration: > 10000 nM
Compound 3 gave a limit, no number (the forecaster's own chance of this, stated with the estimate: 35%); middle value at least 1.6-fold (0.22 log units) from the limit.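

In this assay compound 3 gives only a limit, > 10000 nM, and no number. With furan-2-yl in place of 3-nitrophenyl, the result is an at least 3.5-fold higher number from compound 1 to compound 3 (0.54 log units; beyond the scatter), so compound 2 and compound 3, with two different aromatic rings at this place, both lie on the weaker side of compound 1. The step between compound 2 and compound 3 cannot be read, because both values are limits: the limit of > 10000 nM in this assay, at which 2 of the 3 values shown sit.

From the compounds shown here alone, how the furan-2-yl and 6-methoxypyridin-3-yl groups rank therefore stays open. Also open, going by these compounds, is whether a phenyl ring bearing an amine or a carboxylic acid would keep the measurable value of compound 1.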